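A few compounds are considered here, and "the series" means these few. Any claim that something is new, unique, unknown or untested is made for them only; others in the source may bear on it.

Measured in an ADME assay on microsomes from liver (Homo sapiens) for metabolic stability, read by LC-MS, using NADPH, with stated times of 10 min and 30 min; on this read-out lower numbers stand for slow clearance and higher numbers for fast clearance:
- compound 1 `O=C1c2ccc(Cl)cc2CN1c1cccnc1`: 12.8 mL/min/kg
- compound 2 `CC(=O)N[C@@H]1CCCc2c1cncc2N1C(=O)c2ccc(Cl)cc2[C@@H]1C`: < 3.5 mL/min/kg (a limit of the assay, not a number)
- compound 3 `N#Cc1ccc2c(c1)CN(c1cccnc1)C2=O`: 8.7 mL/min/kg

Going by the values given here, compound 1, with 12.8 mL/min/kg, is one of only two compounds here with a true number. The other is compound 3, with 8.7 mL/min/kg. Among the compounds with values here, the single measured step swaps chloro for cyano on an aromatic carbon: a 1.5-fold lower number from compound 1 to compound 3 (0.17 log units; within the scatter). The reading for compound 2 is a limit, not a number: the limit of < 3.5 mL/min/kg in this assay, at which 1 of the 3 values shown sits. Within the data shown here, compound 2 also differs from compound 1 in more than one place, so it offers no single step to learn from.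

Compound 4 `O=C1c2ccc(Cl)cc2C(C2CC2)N1c1cccnc1` is compound 1 with one change: cyclopropyl in place of hydrogen on a saturated ring carbon. Among the measured compounds shown here, no measured step touches that carbon, so the data give no direct guide to this change. For the measured compounds named here, the one step available, a 1.5-fold lower number from compound 1 to compound 3 (0.17 log units; within the scatter), is the only size on hand, and it gives no reason to expect a move beyond the scatter in this assay. The expected step is a 1.1-fold higher number from compound 1 to compound 4 (0.04 log units; within the scatter). For compound 4 the estimated value is 14 mL/min/kg, with an expected range of 6.5 mL/min/kg to 30 mL/min/kg.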

Compound 4, clearance: 9.4 mL/min/kg
The estimate for compound 4 lay 1.5-fold (0.17 log units) above the measured number, within the range that was stated.
By their numbers in this assay, from the lowest: compounds 3, 4 and 1 (each within the scatter of the next). At a limit, below all of these: compound 2.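

Going by these compounds alone, this is the first reading at the saturated ring carbon next to the ring nitrogen, and in this assay putting cyclopropyl there gives a 1.4-fold lower number from compound 1 to compound 4 (0.13 log units; within the scatter) and so stays within the usual scatter. A ring of three carbons can therefore sit on this carbon, where compound 1 carries only hydrogen, with no shift in clearance that stands out from that scatter. Nothing measured here gives a reason for this result.

On these data alone, whether another group on this carbon, such as an amine, a carboxylic acid or a longer chain, would move clearance beyond the scatter stays open. Compound 2 reads < 3.5 mL/min/kg, a limit of the assay and not a number, and it differs from compound 1 in more than one place, so no single change can be tied to it.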